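The source may report more compounds than this note shows. Statements on the series, on what has been measured and on what is new or still open speak of the compounds shown alone.

Values in a functional assay on HepG2 cells (Homo sapiens) for cytotoxicity, read by MTT assay; on this read-out lower numbers stand for stronger inhibition and higher numbers for weaker inhibition:
compound 1 `CCC(=O)Oc1cc(/C=C/C(=O)c2ccc(OC)c3c2OC(C)(C)C=C3)ccc1OC` gives 90 nM
compound 2 `C=CC(=O)Oc1cc(/C=C/C(=O)c2ccc(OC)c3c2OC(C)(C)C=C3)ccc1OC` gives 160 nM
compound 3 `COc1ccc(/C=C/C(=O)c2ccc(OC)c3c2OC(C)(C)C=C3)cc1OC(=O)C1CC1` gives 220 nM

Compound 3 cannot be separated from compound 2 (a 1.4-fold higher number from compound 2 to compound 3 (0.14 log units; within the scatter)) but stands apart from compound 1 (a 2.4-fold higher number from compound 1 to compound 3 (0.39 log units; beyond the scatter)). Compound 4 `COc1ccc(/C=C/C(=O)c2ccc(OC)c3c2OC(C)(C)C=C3)cc1OS(=O)(=O)Cc1ccccc1` is still unmeasured. It carries benzylsulfonyl in place of cyclopropylcarbonyl on an oxygen on an aromatic ring.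

The measured steps that bear on this only exchange groups on a carbonyl carbon. Besides the two above, there is one more (a 1.8-fold higher number from compound 1 to compound 2 (0.25 log units; within the scatter)). All are small, and none covers a sulfonyl or an added aromatic ring, so they are a weak guide. This change reaches further than those, and a step beyond the scatter is expected in this assay, towards a higher number. Among the measured compounds shown here, the only support for that direction is that the one step beyond the scatter (a 2.4-fold higher number from compound 1 to compound 3 (0.39 log units; beyond the scatter)) also went upward. The expected step is an estimate with wide bounds (a 2.7-fold higher number from compound 3 to compound 4 (0.44 log units; beyond the scatter)). For compound 4 the estimated value is 600 nM (expected range 150 nM to 3000 nM).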

Compound 4, half-maximal inhibitory concentration: > 10000 nM
Compound 4 ended at the assay's limit; the forecaster's own chance of this, stated with the estimate: 5%; middle value at least 16-fold (1.22 log units) from the limit.
By their numbers in this assay, from the lowest: compounds 1, 2 and 3 (each within the scatter of the next, the first and the last beyond it). At a limit, above all of these: compound 4.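

In this assay the reading for compound 4 is a limit, not a number: the limit of > 10000 nM in this assay, at which 1 of the 4 values shown sits.

Until now, this oxygen on an aromatic ring had carried only carbonyl-linked groups, and exchanges among them gave small steps. Benzylsulfonyl gives a step of a different order: an at least 45-fold higher number from compound 3 to compound 4 (1.65 log units; beyond the scatter), an at least 62-fold higher number from compound 2 to compound 4 (1.79 log units; beyond the scatter) and an at least 110-fold higher number from compound 1 to compound 4 (2.04 log units; beyond the scatter). The position therefore accepts propanoyl, vinylcarbonyl and cyclopropylcarbonyl with modest differences, but the series does not keep its cytotoxic reading with benzylsulfonyl there.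

The sulfonyl and the six-membered aromatic ring enter together, so the compounds shown do not separate their shares in this step. Also open, going by these compounds, is how a methylsulfonyl group, a benzoyl group or a free hydroxyl at this position would read in this assay.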